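A pyrazole ester in place of a thiazole ester

The source may report more compounds than this note shows. Statements on the series, on what has been measured and on what is new or still open speak of the compounds shown alone.

Compound 1 `COC(=O)CCNC(=O)[C@@H]1O[P@](=O)(Oc2ccc(C#N)cc2)OCC1(C)C` gives 0.46 h in an ADME assay on blood (Homo sapiens) for pharmacokinetics; on this read-out higher numbers stand for a longer-lived compound and lower numbers for a shorter-lived compound. Compound 2 `COC(=O)CCNC(=O)[C@@H]1O[P@](=O)(OCOC(=O)c2scnc2C)OCC1(C)C` reaches only the limit of < 0.16 h in this assay, a limit rather than a number. Compound 3 `COC(=O)CCNC(=O)[C@@H]1O[P@](=O)(OCOC(=O)c2scnc2C(C)(C)C)OCC1(C)C` gives 0.44 h in this assay, so compound 3 sits together with compound 1 within the usual scatter and the two cannot be told apart. Among the measured compounds shown here, the one measured step, an at least 2.7-fold higher number from compound 2 to compound 3 (0.43 log units; beyond the scatter), is the only guide available. Compound 4 `CCc1cc(C(=O)OCO[P@]2(=O)OCC(C)(C)[C@H](C(=O)NCCC(=O)OC)O2)n(C)n1` differs from compound 3 by 3-ethyl-1-methyl-1H-pyrazol-5-yl in place of 4-(tert-butyl)-1,3-thiazol-5-yl on a carbonyl carbon. This change falls on the same ester group as the measured step and removes the tert-butyl that accompanied the larger number, while an ethyl enters on the new ring; a modest downward step is therefore expected, a 1.5-fold lower number from compound 3 to compound 4 (0.17 log units; within the scatter). Compound 4 is expected to give 0.3 h in this assay, between 0.15 h and 0.6 h.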

Compound 4, half-life: < 0.16 h
Compound 4: only a limit was reported; the forecaster's own chance of this, stated with the estimate: 25%; middle value at least 1.8-fold (0.27 log units) away from the limit.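

Placing 3-ethyl-1-methyl-1H-pyrazol-5-yl in place of 4-(tert-butyl)-1,3-thiazol-5-yl on this carbonyl carbon gives an at least 2.7-fold lower number from compound 3 to compound 4 (0.43 log units; beyond the scatter), so the higher number seen with the tert-butyl thiazole ester does not carry over to this pyrazole ester. In this assay, compound 4 joins compound 2 at a limit rather than a number: the limit of < 0.16 h in this assay, at which 2 of the 4 values shown sit. The step between those two cannot be read.

The change alters the ring and its substituents together, leaving their shares unseparated. Going by these compounds, how an isopropyl group on either ring would behave also stays open.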